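The source may hold more compounds than are shown below. What is called first, only, known or untested is meant among the compounds shown, and "the series" means these compounds.

Of the compounds shown here, three have so far been measured in a functional assay on MKN-45 cells (Homo sapiens) for inhibition, read by MTT assay, with a stated time of 72 h; a higher number here means a weaker inhibitor, a lower number a stronger inhibitor. Compound 1 `COc1cc2c(Oc3ccc(NC(=O)c4nn(-c5ccccc5C)c(=O)cc4C)cc3F)ccnc2cc1OCCCN1CCN(C)CC1` gives 1630 nM. Compound 2 `COc1cc2c(Oc3ccc(NC(=O)c4nn(-c5ccccc5C(F)(F)F)c(=O)cc4C)cc3F)ccnc2cc1OCCCN1CCCC1` gives 100 nM, and compound 3 `COc1cc2c(Oc3ccc(NC(=O)c4nn(-c5ccccc5C(F)(F)F)c(=O)cc4C)cc3F)ccnc2cc1OCCCN1CCC(C)CC1` gives 60 nM. Compound 3 has the lowest of the three numbers, but compound 2 lies within the scatter of it, so these two cannot be ordered; only compound 1 stands apart from compound 3 beyond the scatter. Among the compounds with values here, the one measured single change at the same place on the chain, a 1.7-fold lower number from compound 2 to compound 3 (0.22 log units; within the scatter), shows that exchanging one ring at that place for another moved the number only within the scatter.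

Compound 4 `COc1cc2c(Oc3ccc(NC(=O)c4nn(-c5ccccc5C(F)(F)F)c(=O)cc4C)cc3F)ccnc2cc1OCCCN1CCN(C)CC1` is not yet measured. It differs from compound 3 in one place: 4-methylpiperazin-1-yl in place of 4-methylpiperidin-1-yl on a saturated chain carbon, three bonds along the chain from an oxygen on an aromatic ring. Within the data shown here, no measured pair isolates exactly this exchange. The same 4-methylpiperazin-1-yl group appears in compound 1, which gives 1630 nM, but compound 1 also differs from compound 4 elsewhere in the molecule, so that number cannot be read as a test of this change alone. Because the measured step of a 1.7-fold lower number from compound 2 to compound 3 (0.22 log units; within the scatter) stayed within the scatter, the step of a 1.3-fold higher number from compound 3 to compound 4 (0.12 log units; within the scatter) is expected to be small, with no clear direction beyond the scatter. Compound 4 is therefore estimated at 80 nM, with a range from 30 nM to 250 nM.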

Compound 4, half-maximal inhibitory concentration: 40 nM
Beside the measured number, compound 4's estimate is 2.0-fold (0.30 log units) above it; the range from low to high includes it.
By their numbers in this assay, from the lowest: compounds 4, 3 and 2 (each within the scatter of the next, the first and the last beyond it); then compound 1.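

In this assay, within the data shown here, the exchange on the chain gives a 1.5-fold lower number from compound 3 to compound 4 (0.18 log units; within the scatter) and so does not separate 4-methylpiperazin-1-yl from 4-methylpiperidin-1-yl, whereas a 2.5-fold lower number from compound 2 to compound 4 (0.40 log units; beyond the scatter) is the first ring exchange at this place to go beyond the scatter, though only modestly. Compound 4 also supplies the one-place comparison that was missing for compound 1: with 4-methylpiperazin-1-yl held constant on the chain, trifluoromethyl in place of methyl on an aromatic carbon gives a 41-fold lower number from compound 1 to compound 4 (1.61 log units; beyond the scatter) and this large step shows that the high number of compound 1 cannot be blamed on the ring at the end of the chain. No measurement shown explains the size of either step.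

The compounds shown leave open whether morpholin-4-yl or an open-chain dimethylamino group at the end of the same chain would keep the number in the range of compound 2, compound 3 and compound 4. They also leave open whether a chlorine or a methoxy group on that aromatic carbon would give a number nearer to compound 1 or to compound 4.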